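This account rests on a few compounds, and the source may have more. Where it says the series, first, only, none or still open, it means among the compounds named here.

Measured so far:
compound 1, `N=c1oc2ccccc2cc1C(=O)N/N=C1\C(=O)Nc2ccc(S(=O)(=O)N3CCOCC3)cc21`: 6750 nM
compound 2, `O=C1Nc2ccc(S(=O)(=O)N3CCOCC3)cc2/C1=N/c1ccc(O)cc1`: 27300 nM

Compound 2 stands at the highest of the two numbers in a functional assay on HCT-116 cells (Homo sapiens) for cytotoxicity, read by sulforhodamine B assay, with a stated time of 24 h; a higher number here means a weaker inhibitor, a lower number a stronger inhibitor; the nearest is compound 1, whose number is lower by a margin beyond the scatter, so compound 2 is the weaker inhibitor of the pair. For the measured compounds named here, no two measured compounds differ in one place only, so no single step of known size is available. Compound 3 `O=C1Nc2ccc(S(=O)(=O)N3CCOCC3)cc2/C1=N/NC(=O)c1ccccc1` is next to be measured. Its change from compound 2 is benzamido in place of 4-hydroxyphenyl on a double-bonded nitrogen. Going by the values given here, the only guide is that compound 1, which likewise carries something other than 4-hydroxyphenyl on that double-bonded nitrogen, gives 6750 nM in this assay. A move toward that number is expected, a step of a 2.7-fold lower number from compound 2 to compound 3 (0.44 log units; beyond the scatter) downward, beyond the scatter. Compound 3 is therefore estimated at 10000 nM, expected within 3000 nM to 35000 nM.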

Compound 3, half-maximal inhibitory concentration: 28900 nM
Compound 3: the middle estimate sits 2.9-fold (0.46 log units) below what was measured; the measured number falls inside the stated range.
By their numbers in this assay, from the lowest: compound 1; then compounds 2 and 3 (each within the scatter of the next).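

On the double-bonded nitrogen, benzamido in place of 4-hydroxyphenyl gives a 1.1-fold higher number from compound 2 to compound 3 (0.02 log units; within the scatter) in this assay, so this position does not separate these two groups in this assay. Compound 1 and compound 3 share the link through the carbonyl carbon, and the group of 6 heavy atoms on that carbon in place of the group of 11 heavy atoms gives a 4.3-fold higher number from compound 1 to compound 3 (0.63 log units; beyond the scatter), which places the difference between them at the carbonyl carbon rather than at the double-bonded nitrogen. No measurement at hand accounts for either step.

For the compounds shown here, the single pair leaves open whether a smaller group on the carbonyl carbon, such as a methyl or a short alkyl chain, follows the same direction. Also open, going by these compounds, is how an amine or a carboxylic acid on the benzene ring of benzamido would read in this assay.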